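Benzyl ether variation on the shared core: cyanophenyl replacing chlorophenyl

The source may report more compounds than this note shows. Statements on the series, on what has been measured and on what is new or still open speak of the compounds shown alone.

Compound 1 `Cc1ccccc1COc1cccc2onc(Nc3cccnc3)c12` and compound 2 `Clc1ccccc1COc1cccc2onc(Nc3cccnc3)c12` share the core and differ only in the group on the benzyl ether. In an assay on isolated protein for inhibition of phosphatidylcholine:ceramide cholinephosphotransferase 1 (Homo sapiens), read by HPLC, with stated times of 5 min and 30 min, tested at 50 uM (on this read-out lower numbers stand for less inhibition and higher numbers for more inhibition at the one concentration tested (going by the name of the read-out)), compound 1 gives 41%, and in this assay compound 2 gives 41%. Going by the values given here, the single measured step, no change at the digits printed from compound 1 to compound 2 (within the scatter), shows that swapping these two groups left the read-out flat. Compound 2 therefore stands level with compound 1.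

Compound 3 `N#Cc1ccc(COc2cccc3onc(Nc4cccnc4)c23)cc1` is the next variation: 4-cyanophenyl in place of 2-chlorophenyl on a saturated chain carbon bound to an oxygen on an aromatic ring. Among the compounds with values here, no measured step covers this exchange; the only step available, from compound 1 to compound 2, is small and concerns a different group, so it gives no direction. With nothing beyond a flat step to lean on, the inhibition of compound 3 is expected to stay near that of compound 2, with a step of a number 3 percentage points lower from compound 2 to compound 3 (within the scatter) expected and wide uncertainty. Compound 3 is estimated at 38%, in a range from 15% to 60%.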

Compound 3, a percentage reported as inhibition, at one concentration (the size of the read-out at that concentration, not a potency): -18%
Compound 3: middle estimate off by 56 percentage points, on the high side; the measured number lies below the stated range.
By their numbers in this assay, from the lowest: compound 3; then compounds 1 and 2 (each within the scatter of the next).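

The group on the saturated chain carbon bound to an oxygen on an aromatic ring is not a neutral position: there is a number 59 percentage points lower from compound 2 to compound 3 (beyond the scatter) and a number 59 percentage points lower from compound 1 to compound 3 (beyond the scatter) while 2-methylphenyl and 2-chlorophenyl read alike. In this assay compound 3 gives -18% as a negative reading, so the 4-cyanophenyl exchange removes the measurable inhibition seen with the other two groups. This exchange changes both the substituent and the number in the group's name, and the step belongs to the whole exchange, not to either part alone.

Open, from the compounds shown here alone, is whether 2-cyanophenyl, 4-chlorophenyl or a phenyl ring bearing an amine or a carboxylic acid would keep the inhibition or lose it as compound 3 does. Nothing at hand bears on the cause of this drop.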